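Benzothiophenyl for tert-butylpyrazolyl: expected clearance of compound 3

A few compounds are considered here, and "the series" means these few. Any claim that something is new, unique, unknown or untested is made for them only; others in the source may bear on it.

Measured compounds:
compound 1 `CC(C)(C)n1cc(-c2cc(C(O)(C(F)(F)F)C(F)(F)F)cnc2N2CCN(S(=O)(=O)c3ccc(N)nc3)CC2)cn1`: 86 mL.min-1.g-1
compound 2 `Nc1ccc(S(=O)(=O)N2CCN(c3ncc(C(O)(C(F)(F)F)C(F)(F)F)cc3-c3cccc(F)c3)CC2)cn1`: 25 mL.min-1.g-1

Among the measured compounds shown here, in an ADME assay (liver) for metabolic stability, with Liver microsome (Homo sapiens) as the target, using microsomes and NADPH, with a stated time of 30 min, tested at 1 uM (on this read-out lower numbers stand for slow clearance and higher numbers for fast clearance), compound 1 gives 86 mL.min-1.g-1, the highest of the two numbers; its nearest neighbour is compound 2, which gives 25 mL.min-1.g-1, and the one measured step, a 3.4-fold lower number from compound 1 to compound 2 (0.54 log units; beyond the scatter), replaces 1-(tert-butyl)-1H-pyrazol-4-yl with 3-fluorophenyl on an aromatic carbon.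

Compound 3 `Nc1ccc(S(=O)(=O)N2CCN(c3ncc(C(O)(C(F)(F)F)C(F)(F)F)cc3-c3ccc4sccc4c3)CC2)cn1` is not yet measured. It differs from compound 1 in the same place: 1-benzothiophen-5-yl in place of 1-(tert-butyl)-1H-pyrazol-4-yl on an aromatic carbon. As in compound 2, the group that leaves is the 1-(tert-butyl)-1H-pyrazol-4-yl; what enters is 1-benzothiophen-5-yl instead of 3-fluorophenyl. The step from compound 1 to compound 2 is the only one that bears on this change, and it lowered the number beyond the scatter. For the measured compounds named here, a step in the same direction is therefore expected for compound 3, though an aryl of this size has no direct precedent here, so the expected step of a 1.9-fold lower number from compound 1 to compound 3 (0.28 log units; within the scatter) is held somewhat below that of compound 2. Compound 3 is thus estimated at 45 mL.min-1.g-1 in this assay, within 18 mL.min-1.g-1 to 110 mL.min-1.g-1.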

Compound 3, intrinsic clearance in microsomes: 48 mL.min-1.g-1
Compound 3: the middle estimate sits 1.1-fold (0.03 log units) below what was measured; measured number inside the range.
By their numbers in this assay, from the lowest: compounds 2, 3 and 1 (each within the scatter of the next, the first and the last beyond it).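

In this assay the step of a 1.8-fold lower number from compound 1 to compound 3 (0.25 log units; within the scatter) stays inside the scatter, so this exchange of the 1-(tert-butyl)-1H-pyrazol-4-yl for another group of 9 heavy atoms does not separate the two compounds, as the move to 3-fluorophenyl did. The step of a 1.9-fold higher number from compound 2 to compound 3 (0.28 log units; within the scatter) also stays inside the scatter, which leaves compound 3 indistinguishable from both of its neighbours, even though compound 1 and compound 2 stand apart from each other. At this aromatic carbon, the clear step seen earlier therefore cannot be read as a general result of replacing the 1-(tert-butyl)-1H-pyrazol-4-yl with a carbon-only or sulfur-containing aromatic group, since only 3-fluorophenyl gives a step beyond the scatter. No evidence is available on what lies behind these readings.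

The compounds shown leave open whether a plain phenyl ring at this place would stand with compound 2 or with compound 1. They also leave open how a ring holding an amine, such as morpholine, or an aryl group bearing a carboxylic acid would read here.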